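The source may hold more compounds than are shown below. What is called first, only, known or untested is meant among the compounds shown, and "the series" means these compounds.

Measured so far in an assay on membranes from HeLa cells for displacement of a labelled ligand from adenosine receptor A3 (Homo sapiens), read by scintillation counting, with a stated time of 180 min, tested at 1 uM; a higher number here means more inhibition at the concentration tested (going by the name of the read-out), a lower number less inhibition:

compound 1 `CCNC(=O)C1=C(C)NC(=O)NC1c1ccoc1`: 1%
compound 2 `CCNC(=O)C1=C(C)NC(=O)NC1c1ccsc1`: 1%
compound 3 `CC1=C(c2ncc(C)o2)C(c2ccoc2)NC(=O)N1`: 1%

Compound 1 stands level with compound 2 and compound 3 at the digits shown, and all three sit at the bottom of the read-out. The step of no change at the digits printed from compound 1 to compound 2 (within the scatter) came with thiophen-3-yl in place of furan-3-yl on a saturated ring carbon, and the step of no change at the digits printed from compound 1 to compound 3 (within the scatter) with 5-methyl-1,3-oxazol-2-yl in place of ethylcarbamoyl on a double-bonded ring carbon. Neither change moved the read-out beyond the scatter.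

Compound 4 `CC1=C(C(=O)OCC2CCC2)C(c2ccoc2)NC(=O)N1` has not yet been measured in this assay. It differs from compound 1 as follows: cyclobutylmethoxy in place of ethylamino on a carbonyl carbon. Among the measured compounds shown here, of the measured steps, the one from compound 1 to compound 3 is the nearer comparison, since it too reworks the group attached to the double-bonded ring carbon, whereas the change to compound 4 keeps the carbonyl and swaps only what sits on it. Because no change at the digits printed from compound 1 to compound 3 (within the scatter) showed no movement, and because no change at the digits printed from compound 1 to compound 2 (within the scatter) showed none either, the step of a number 2 percentage points higher from compound 1 to compound 4 (within the scatter) is expected to stay within the scatter, with no direction to it. Compound 4 is therefore estimated at 3%, within a range from -8% to 18%.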

Compound 4, a percentage reported as inhibition, at one concentration (the size of the read-out at that concentration, not a potency): 2%
Compound 4: middle estimate off by 1 percentage points, on the high side, within the range that was stated.
By their numbers in this assay, from the lowest: compounds 1, 2, 3 and 4 (each within the scatter of the next).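

In this assay, putting cyclobutylmethoxy in place of ethylamino on the carbonyl carbon gave a number 1 percentage points higher from compound 1 to compound 4 (within the scatter) and left compound 4 at the bottom of the read-out, like the other compounds. The earlier steps shown here had replaced the ring on the saturated carbon or the whole carbonyl-bearing group, whereas this one keeps the carbonyl and shows that exchanging what sits on it, with the hydrogen-bond donor of ethylamino leaving and a larger group with a four-membered carbon ring entering, also produces no change beyond the scatter. No measurement shown here explains why the read-out stays so low across these changes.

With all four compounds this low, the data cannot show whether any group on this carbonyl carbon can raise the inhibition, so a benzylamino group, a carboxylic acid or a longer alkoxy chain such as octyloxy remains an open case. Also open, going by these compounds, is whether cyclobutylmethoxy would give the same reading with thiophen-3-yl in place of furan-3-yl on the saturated ring carbon.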